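Uracil alkynes with a phthalimide linker: alkyl against aryl

The source may hold more compounds than are shown below. What is called first, only, known or untested is meant among the compounds shown, and "the series" means these compounds.

Among the measured compounds shown here, in a functional assay on L1210 cells (Mus musculus) for antiproliferative activity, read by MTT assay, with a stated time of 2 days (a higher number here means a weaker inhibitor, a lower number a stronger inhibitor), compound 3 `CCCCCCC#Cc1cn(C/C=C/CN2C(=O)c3ccccc3C2=O)c(=O)[nH]c1=O` gives 43000 nM and stands lowest of the three numbers measured so far. Compound 1 `Cc1ccc(C#Cc2cn(C/C=C\CN3C(=O)c4ccccc4C3=O)c(=O)[nH]c2=O)cc1` gives 245000 nM in this assay, and compound 2 `O=C1c2ccccc2C(=O)N1C/C=C\Cn1cc(C#Cc2ccc(Br)cc2)c(=O)[nH]c1=O` gives 448000 nM. For the measured compounds named here, the one single-point step among them, a 1.8-fold higher number from compound 1 to compound 2 (0.26 log units; within the scatter), is small. Compound 4 `CCCCCc1ccc(C#Cc2cn(C/C=C/CN3C(=O)c4ccccc4C3=O)c(=O)[nH]c2=O)cc1` is not yet measured in this assay; it differs from compound 3 by 4-pentylphenyl in place of hexyl on a triple-bonded carbon. Going by the values given here, no measured step exchanges an alkyl chain for an aryl group on the triple-bonded carbon under otherwise equal conditions, so the bearing of the measured pairs is indirect: both compounds carrying an aryl group on that carbon, compound 1 and compound 2, gave clearly higher numbers than compound 3. From that alone, a step toward a higher number beyond the scatter is expected, a 3.0-fold higher number from compound 3 to compound 4 (0.48 log units; beyond the scatter), though the new group keeps a pentyl chain and the outcome is uncertain. Compound 4 is therefore estimated at 130000 nM in this assay, within a range from 40000 nM to 400000 nM.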

Compound 4, half-maximal inhibitory concentration: 39000 nM
Compound 4: middle estimate off by 3.3-fold (0.52 log units), on the high side; measured number below the stated range.
By their numbers in this assay, from the lowest: compounds 4 and 3 (each within the scatter of the next); then compounds 1 and 2 (each within the scatter of the next).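

In this assay, among the compounds shown here, 4-pentylphenyl in place of hexyl on a triple-bonded carbon gives a 1.1-fold lower number from compound 3 to compound 4 (0.04 log units; within the scatter), so this is the first direct exchange at this position, and it shows that an aromatic ring carrying a pentyl chain and a plain hexyl chain cannot be told apart here. Compound 1 and compound 2 also carry an aryl group on that carbon, but each differs from compound 3 in more than one place, so their higher numbers cannot be assigned to the aryl group itself. Nothing measured here explains why the two groups read alike.

The compounds shown leave open whether a chain longer than hexyl would change the number at this position. They also leave open what an amine or a carboxylic acid in place of the pentyl chain would do.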